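Saturating the 2-cyanoethenyl chain of compound 1

A few compounds are considered here, and "the series" means these few. Any claim that something is new, unique, unknown or untested is made for them only; others in the source may bear on it.

In an ADME assay on TZM cells (Homo sapiens) for cytotoxicity, read by XTT assay, with a stated time of 4 days (on this read-out higher numbers stand for lower toxicity in this test and lower numbers for higher toxicity in this test), compound 1 `CNC(=O)c1cc2ncn(-c3ccc(C#N)cc3)c2cc1Oc1c(C)cc(/C=C/C#N)cc1C` gives > 890000 nM as a limit of the assay, not a number. Numbers are available only for compound 2 `Cc1cc(N)cc(C)c1Oc1cc(Nc2ccc(C#N)cc2)c(N)cc1C(F)(F)F` at 15800 nM and compound 3 `Cc1cc(CO)cc(C)c1Oc1cc(Nc2ccc(C#N)cc2)c(N)cc1CO` at 15900 nM, and these two lie within the scatter of each other. Compound 4 `CNC(=O)c1cc2ncn(-c3ccc(C#N)cc3)c2cc1Oc1c(C)cc(CCC#N)cc1C` differs from compound 1 by 2-cyanoethyl in place of 2-cyanoethenyl on an aromatic carbon. Going by the values given here, no step between measured compounds is available to size this change. A modest step toward lower numbers in this assay is expected, or none beyond the scatter, and the estimated step of an at least 1.4-fold lower number from compound 1 to compound 4 (0.17 log units; that floor lies within the scatter) runs that way. For compound 4 the estimate is 600000 nM, with an expected range from 100000 nM to 1000000 nM as its ends.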

Compound 4, half-maximal cytotoxic concentration: > 890000 nM
Compound 4: only a limit was reported (the forecaster's own chance of this, stated with the estimate: 55%); middle value at least 1.4-fold (0.17 log units) from the limit.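

Compound 1 and compound 4 are both reported only as limits in this assay, so no step between them can be read: the limit of > 890000 nM in this assay, at which 2 of the 4 values shown sit.

As far as these compounds go, whether 2-cyanoethyl in place of 2-cyanoethenyl changes this read-out at all remains open.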